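A few compounds are considered here, and "the series" means these few. Any claim that something is new, unique, unknown or untested is made for them only; others in the source may bear on it.

Compounds measured in a functional assay on HepG2 cells (Homo sapiens) for antiproliferative activity, read by MTT assay, with a stated time of 48 h; on this read-out higher numbers stand for weaker inhibition and lower numbers for stronger inhibition:
compound 1 `N#CC1=C(N)Oc2c(c3nc4ccccc4nc3c3ccccc23)C12C(=O)N(Cc1cnnn1-c1ccc([N+](=O)[O-])cc1)c1ccccc12` gives > 50000 nM, a limit of the assay.
compound 2 `N#CC1=C(N)Oc2c(c3nc4ccccc4nc3c3ccccc23)C12C(=O)N(Cc1cnnn1-c1ccc(F)c(Cl)c1)c1ccccc12` gives > 50000 nM, likewise a limit.
compound 3 `CC(=O)Nc1ccc(-n2nncc2CN2C(=O)C3(C(C#N)=C(N)Oc4c(N)cc5nc6ccccc6nc5c43)c3ccccc32)cc1` gives > 50000 nM, again a limit and not a number.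

Compound 3 therefore stands only at a limit, and the two further values shown are limits as well; no ordering among the three can be read. Among the measured compounds shown here, the single step between compounds differing in one place, a step that the two limits leave unreadable from compound 1 to compound 2, is left unreadable by the two limits. For the measured compounds named here, the only evidence is the limit of > 50000 nM in this assay, at which 3 of the 3 values shown sit.

Compound 4 `COc1cc(-n2nncc2CN2C(=O)C3(C(C#N)=C(N)Oc4c(N)cc5nc6ccccc6nc5c43)c3ccccc32)c(OC)cc1Cl` differs from compound 3 by 4-chloro-2,5-dimethoxyphenyl in place of 4-acetamidophenyl on an aromatic nitrogen. Going by the values given here, no measured step bears on this change, so no shift beyond the scatter is expected in either direction. Compound 4 is expected to give about 60000 nM, with a range from 20000 nM to 200000 nM. The expected step that the limit leaves unreadable from compound 3 to compound 4 is thus essentially none, and a further limit is the likeliest outcome.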

Compound 4, half-maximal inhibitory concentration: > 50000 nM
Compound 4 was reported as a limit; the forecaster's own chance of this, stated with the estimate: 80%; the middle value is on the limit's open side.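

In this assay, among the compounds shown here, compound 4 gives > 50000 nM, a limit and not a number; compound 3 also stands at a limit, so no step between them can be read. The compounds shown leave open how they rank and whether any group on the aromatic nitrogen changes the read-out: the limit of > 50000 nM in this assay, at which 4 of the 4 values shown sit.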